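One Ring Swap and Its Expected Cell Toxicity

The source may hold more compounds than are shown below. What is called first, only, known or untested is meant among the compounds shown, and "the series" means these compounds.

In an ADME assay on MT4 cells (Homo sapiens) for cytotoxicity, read by MTT assay, with a stated time of 4 days (on this read-out lower numbers stand for higher toxicity in this test and higher numbers for lower toxicity in this test), compound 1 `C/C(=N\NC(=O)COc1cccc2ccccc12)c1ccc(C#N)cc1Br` gives 12.1 ug/mL. Compound 2 `O=C(COc1cccc2ccccc12)N/N=C/c1ccccc1Br` gives 11.4 ug/mL, a number within the scatter of that of compound 1. Compound 3 `O=C(COc1cccc2ccccc12)N/N=C/c1ccc([N+](=O)[O-])cc1` gives 87.9 ug/mL, which lies beyond the scatter from compound 1. Compound 1 therefore stands level with compound 2 and well under compound 3. Compound 4 `C/C(=N\NC(=O)COc1cccc2ccccc12)c1ccccc1O` has not yet been measured. It carries 2-hydroxyphenyl in place of 2-bromo-4-cyanophenyl on a carbon with a double bond to nitrogen. Among the measured compounds shown here, no measured pair shows this change alone, so only a modest rise in the number is expected, and it may stay within the scatter. The expected step is a 1.8-fold higher number from compound 1 to compound 4 (0.26 log units; within the scatter). For compound 4 the estimate is 22 ug/mL, with a range of 6 ug/mL to 80 ug/mL.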

Compound 4, half-maximal cytotoxic concentration: 11.3 ug/mL
Compound 4: middle estimate off by 1.9-fold (0.29 log units), on the high side; the measured number falls inside the stated range.
By their numbers in this assay, from the lowest: compounds 4, 2 and 1 (each within the scatter of the next); then compound 3.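

In this assay the exchange of 2-bromo-4-cyanophenyl for 2-hydroxyphenyl gives a 1.1-fold lower number from compound 1 to compound 4 (0.03 log units; within the scatter) on the carbon with a double bond to nitrogen. At this position, then, losing the bromine and the nitrile and gaining a hydrogen-bond donor leaves the read-out unmoved within the scatter. No measurement shown here explains this. Still open, as far as these compounds go, is whether a carboxylic acid or an amine on this ring would shift the number, since only a group with a hydroxyl has replaced the bromo-cyano ring here.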